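The source may report more compounds than this note shows. Statements on the series, on what has been measured and on what is new or still open speak of the compounds shown alone.

Measured so far:
compound 1 `CN(Cc1nc(C2CCN(Cc3ccc(F)cc3)CC2)no1)c1ncc(C(=O)NO)cn1` — 65%
compound 2 `CN(Cc1nc(C2CCN(Cc3ccc(C(F)(F)F)cc3)CC2)no1)c1ncc(C(=O)NO)cn1` — 30%

Within the data shown here, in an assay on isolated protein for inhibition of protein deacetylase HDAC6 (Homo sapiens), read by fluorescence, with a stated time of 1 h, tested at 100 nM (on this read-out higher numbers stand for more inhibition at the one concentration tested (going by the name of the read-out) and lower numbers for less inhibition), compound 2 stands lowest of the two numbers; the nearest is compound 1, and the one step between them, a number 35 percentage points lower from compound 1 to compound 2 (beyond the scatter), is large and beyond the scatter. Compound 3 `CN(Cc1nc(C2CCN(Cc3ccc(F)cc3F)CC2)no1)c1ncc(C(=O)NO)cn1` differs from compound 2 by 2,4-difluorophenyl in place of 4-(trifluoromethyl)phenyl on a saturated chain carbon bound to an amine nitrogen in a ring. Among the measured compounds shown here, only that one step bears on it: removing trifluoromethyl in favour of a fluoro-bearing ring reversed the earlier loss, so a rise is expected, estimated as a number 25 percentage points higher from compound 2 to compound 3 (beyond the scatter). Compound 3 is therefore expected to give 55%, within 35% to 75%.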

Compound 3, a percentage reported as inhibition, at one concentration (the size of the read-out at that concentration, not a potency): 66%
Compound 3: the middle estimate sits 11 percentage points below what was measured; the measured number falls inside the stated range.
By their numbers in this assay, from the lowest: compound 2; then compounds 1 and 3 (each within the scatter of the next).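

In this assay, 2,4-difluorobenzyl in place of 4-(trifluoromethyl)benzyl gives a number 36 percentage points higher from compound 2 to compound 3 (beyond the scatter), so the low number of compound 2 does not extend to every substituted benzyl at this place. Fluoro in place of hydrogen on an aromatic carbon gives a number 1 percentage points higher from compound 1 to compound 3 (within the scatter), so in this pair the added fluoro brings no readable change. Nothing at hand accounts for either step.

Open, as far as these compounds go, is whether a methoxy group or a nitrile on the benzyl ring would keep the inhibition of compound 1. Also open, from the compounds shown here alone, is how a phenethyl group would compare with the benzyl group.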